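Enantiomer swap on the hydroxycyclohexyl spiro series

This account rests on a few compounds, and the source may have more. Where it says the series, first, only, none or still open, it means among the compounds named here.

Measured so far:
compound 1 `CC1(CC(F)(F)F)NC(=O)c2sc(-c3ccncc3)cc2N1` gives 31 nM
compound 2 `Cc1n[nH]cc1-c1cc2c(s1)C(=O)N[C@]1(CC[C@](O)(C3CCCCC3)CC1)N2` gives 2900 nM

Compound 2 has the highest number of the two on an assay for inhibition of Rho-associated protein kinase 1 (Homo sapiens), read by TR-FRET, with stated times of 5 min and 2 h; on this read-out higher numbers stand for weaker inhibition and lower numbers for stronger inhibition; compound 1 stands far lower, and the gap between them lies beyond the scatter. Among the measured compounds shown here, no step between two measured compounds that differ in one place is available, so the series gives no direct guide for what follows.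

Compound 3 `Cc1n[nH]cc1-c1cc2c(s1)C(=O)N[C@]1(CC[C@@](O)(C3CCCCC3)CC1)N2` is the mirror image of compound 2: the two compounds have the same atoms and bonds and differ only in configuration as drawn: 2 of 2 stereo elements differ (all stereocentres are inverted: mirror images); a stereocentre at a saturated ring carbon is drawn s in compound 2 and r in compound 3; a stereocentre at a saturated ring carbon is drawn s in compound 2 and r in compound 3. Nothing leaves and nothing enters; only the drawn configuration changes. For the measured compounds named here, with no measured pair of mirror images in hand, the size and direction of the step cannot be read from the data. Since compound 2 sits high at 2900 nM, there is more room for the number to fall than to rise, and a sizeable step in either direction would not be surprising for mirror images.

The expectation is that compound 3 comes in stronger than compound 2, with the step of a 5.8-fold lower number from compound 2 to compound 3 (0.76 log units; beyond the scatter) estimated, though with wide uncertainty. Compound 3 is estimated at 500 nM, in the range 50 nM to 5000 nM.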

Compound 3, half-maximal inhibitory concentration: 350 nM
Estimate against measurement, compound 3: 1.4-fold (0.15 log units) above, and the stated range covers the measured number.
By their numbers in this assay, from the lowest: compound 1; then compound 3; then compound 2.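

In this assay, among the compounds shown here, the pair gives the first step between compounds that differ in one place: an 8.3-fold lower number from compound 2 to compound 3 (0.92 log units; beyond the scatter). With nothing leaving and nothing entering, drawn configuration alone is enough to move the number beyond the scatter on this scaffold, which neither of the two earlier values could show when taken separately. The direction is also now fixed for this pair, with the lower number belonging to the isomer whose two stereocentres are drawn r, and the step traces to configuration alone: the fact that compounds 2 and 3 differ only in the configuration as drawn

Both stereocentres invert together in this pair, so what each one contributes on its own cannot be read, and a compound with only one of them inverted would be needed to separate the two. On these data alone, it also remains open whether a configuration step of this size and direction would persist with an amine in place of the hydroxyl group, or with a carboxylic acid on the ring in place of the cyclohexyl group.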